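Notes on the semicarbazide series in NCI-H460 cell inhibition

This account rests on a few compounds, and the source may have more. Where it says the series, first, only, none or still open, it means among the compounds named here.

Measured so far:
- compound 1, `COc1cc(NC(C)CCCNC(=O)NNC(=O)Nc2ccc(Br)cc2)c2ncccc2c1`: 27000 nM
- compound 2, `COc1cc(NC(C)CCCNC(=O)Nc2ccc(O)cc2)c2ncccc2c1`: 34000 nM
- compound 3, `COc1cc(NC(C)CCCNC(=O)NNC(=O)Nc2cccc(C(F)(F)F)c2)c2ncccc2c1`: 20000 nM

All three values come from a functional assay on NCI-H460 cells (Homo sapiens) for inhibition, read by MTT assay, with a stated time of 72 h; a lower number here means a stronger inhibitor, a higher number a weaker inhibitor. Compound 3 gives the lowest number of the three, but its steps to compound 1 and to compound 2 both lie within the scatter, so no order among them can be read.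

Compound 4, `COc1cc(NC(C)CCCNC(=O)NNC(=O)Nc2ccc(O)cc2)c2ncccc2c1`, differs from compound 3 by 4-hydroxyphenyl in place of 3-(trifluoromethyl)phenyl on an amide-type nitrogen. Going by the values given here, two measured steps bear on this: a 1.4-fold lower number from compound 1 to compound 3 (0.13 log units; within the scatter), and a 1.3-fold higher number from compound 1 to compound 2 (0.10 log units; within the scatter). Both are within the scatter, and the aryl-group changes across the series have so far moved the number little. Compound 4 is therefore expected to give 28000 nM in this assay, between 14000 nM and 56000 nM, which means an expected step of a 1.4-fold higher number from compound 3 to compound 4 (0.15 log units; within the scatter), not beyond the scatter.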

Compound 4, half-maximal inhibitory concentration: > 100000 nM
Compound 4 was reported as a limit; the forecaster's own chance of this, stated with the estimate: 10%; at least 3.5-fold (0.55 log units) between middle value and limit.
By their numbers in this assay, from the lowest: compounds 3, 1 and 2 (each within the scatter of the next). At a limit, above all of these: compound 4.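

Compound 4 stands only as a limit, not as a number: the limit of > 100000 nM in this assay, at which 1 of the 4 values shown sits.

The aryl group on this amide-type nitrogen can matter after all: the change gives an at least 5.0-fold higher number from compound 3 to compound 4 (0.69 log units; beyond the scatter), and hydroxy in place of bromo on an aromatic carbon gives an at least 3.7-fold higher number from compound 1 to compound 4 (0.56 log units; beyond the scatter). The 4-hydroxyphenyl group alone does not set the result, since ((4-hydroxyphenyl)carbamoyl)amino in place of 4-hydroxyphenyl gives an at least 2.9-fold higher number from compound 2 to compound 4 (0.46 log units; beyond the scatter).

Open, from the compounds shown here alone, is whether this step belongs to hydroxy specifically: methoxy or an amine in place of hydroxy on that aromatic carbon would test this. Going by these compounds, how far compound 4 lies past its limit also stays open.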